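Methoxy for methyl across two cores in MCF7 cells

The source may hold more compounds than are shown below. What is called first, only, known or untested is meant among the compounds shown, and "the series" means these compounds.

Compound 1 `Cc1ccc(-c2c(CN3CCCCC3)nc3scc(C(=O)O)n23)cc1` and compound 2 `COc1ccc(-c2c(CN3CCCCC3)nc3scc(C(=O)O)n23)cc1` share one core. In a functional assay on MCF7 cells (Homo sapiens) for antiproliferative activity, read by MTT assay, with a stated time of 72 h (a higher number here means a weaker inhibitor, a lower number a stronger inhibitor), compound 1 gives 8290 nM, and compound 2 gives 62900 nM. The change between them, (methoxy in place of methyl on an aromatic carbon), produced a 7.6-fold higher number from compound 1 to compound 2 (0.88 log units; beyond the scatter).

Compound 3 `CC(=O)NNC(=O)c1csc2ncc(-c3ccc(C)cc3)n12` rests on a different core; the difference between the two cores is not broken down here. In this assay compound 3 gives 57300 nM. Compound 4 `COc1ccc(-c2cnc3scc(C(=O)NNC(C)=O)n23)cc1` carries the same change on that core, (methoxy in place of methyl on an aromatic carbon), at a place described in the same words as before.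

For the measured compounds named here, with only one earlier example, which itself is modest in size, the step from compound 3 to compound 4 is expected to be a 3.5-fold higher number from compound 3 to compound 4 (0.54 log units; beyond the scatter), because on the first core the same change gave a 7.6-fold higher number from compound 1 to compound 2 (0.88 log units; beyond the scatter). Compound 4 is therefore estimated at 200000 nM, between 60000 nM and 700000 nM.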

Compound 4, half-maximal inhibitory concentration: 8360 nM
Estimate against measurement, compound 4: 24-fold (1.38 log units) above; the whole stated range lies above it.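

In this assay, methoxy in place of methyl on the second core gave a 6.9-fold lower number from compound 3 to compound 4 (0.84 log units; beyond the scatter), the opposite direction to that seen on the first core. The change therefore did not carry over between these two cores: the same change on two cores in this assay, a 7.6-fold higher number (0.88 log units; beyond the scatter) from compound 1 to compound 2 and a 6.9-fold lower number (0.84 log units; beyond the scatter) from compound 3 to compound 4, 52-fold (1.72 log units) apart, beyond the scatter of two such steps. This shows that, for these two pairs, the direction of the step on one core did not hold on the other, but with a single pair on each core it does not show which difference between the cores is responsible, nor how the change behaves on any other core.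

The compounds shown leave open how an amine or a chlorine at the same place would behave on either core. They also leave open whether an ethyl group would follow methyl or methoxy.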